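The source may report more compounds than this note shows. Statements on the series, on what has been measured and on what is new or still open speak of the compounds shown alone.

In a functional assay on MDA-MB-231 cells (Homo sapiens) for inhibition, read by MTT assay, with a stated time of 72 h (a lower number here means a stronger inhibitor, a higher number a weaker inhibitor), compound 1 `O=C(CSc1nc(Nc2ccccc2)c2ccccc2n1)Nc1cccc(Br)c1` gives 17500 nM. Compound 2 `O=C(CSc1nc(Nc2ccccc2)c2ccccc2n1)Nc1cccc([N+](=O)[O-])c1` differs from it in one place, (nitro in place of bromo on an aromatic carbon), and in this assay compound 2 gives 33000 nM; the step between the two is a 1.9-fold higher number from compound 1 to compound 2 (0.28 log units; within the scatter). Compound 3 `C=CC(=O)Nc1cccc(NC(=O)CSc2nc(Nc3cccc(Br)c3)c3ccccc3n2)c1` is built on a different core; how its core differs from the core of compound 1 is not broken down here. In this assay compound 3 gives 19400 nM. Compound 4 `C=CC(=O)Nc1cccc(NC(=O)CSc2nc(Nc3cccc([N+](=O)[O-])c3)c3ccccc3n2)c1` has not yet been measured in this assay. It differs from compound 3 by nitro in place of bromo on an aromatic carbon, the same change, at the same place, that turns compound 1 into compound 2. The expected step is a 1.8-fold higher number from compound 3 to compound 4 (0.26 log units; within the scatter), because the same change once gave a 1.9-fold higher number from compound 1 to compound 2 (0.28 log units; within the scatter), a step that stays within the usual scatter of this assay, so little movement is expected here either. On that single precedent, compound 4 is estimated at 35000 nM in this assay, with a likely range from 17000 nM to 70000 nM.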

Compound 4, half-maximal inhibitory concentration: > 50000 nM
Compound 4 gave a limit, no number; the forecaster's own chance of this, stated with the estimate: 10%; at least 1.4-fold (0.15 log units) between middle value and limit.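

In this assay compound 4 gives > 50000 nM, which is a limit of the assay and not a number. Putting nitro in place of bromo on the core of compound 3 gives an at least 2.5-fold higher number from compound 3 to compound 4 (0.41 log units; beyond the scatter), a loss of inhibition that can be read, whereas the same change on the core of compound 1 stays within the scatter. This shows that the change can weaken inhibition on the core of compound 3, but it does not show whether the change does more on one core than on the other: the same change on two cores in this assay, a 1.9-fold higher number (0.28 log units; within the scatter) from compound 1 to compound 2 and an at least 2.5-fold higher number (0.41 log units; beyond the scatter) from compound 3 to compound 4; the limit leaves it open whether they differ.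

With only bromo and nitro shown at this place, the compounds leave open how an amine, a nitrile or a methoxy group there would behave on either core. Within the data shown here, each core also offers only one pair for this change, and one of the values is a limit rather than a number: the limit of > 50000 nM in this assay, at which 1 of the 4 values shown sits.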